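The source may report more compounds than this note shows. Statements on the series, on what has been measured and on what is new or still open speak of the compounds shown alone.

Measured compounds:
- compound 1 `O=C1c2ccccc2S(=O)(=O)N1CCCCCCN1CCN(c2cccc(Cl)c2Cl)CC1`, which in an ADME assay on HEK293 cells for displacement of a labelled ligand from 5-hydroxytryptamine receptor 7 (Homo sapiens), read by radioligand binding, with a stated time of 1 h (on this read-out higher numbers stand for weaker inhibition and lower numbers for stronger inhibition), gives 119 nM
- compound 2 `O=C1c2ccccc2S(=O)(=O)N1CCCCCCN1CCN(c2cccc3ccccc23)CC1`, which in this assay gives 20 nM

Within the data shown here, compound 2 stands with the lowest of the two numbers; its nearest neighbour is compound 1, and the only step available runs a 6.0-fold lower number from compound 1 to compound 2 (0.77 log units; beyond the scatter). That step was brought about by putting naphthalen-1-yl in place of 2,3-dichlorophenyl on the amine nitrogen in the ring.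

Compound 3 `O=C1c2ccccc2S(=O)(=O)N1CCCCCCN1CCN(c2cccc3cccnc23)CC1` has not yet been measured. It differs from compound 2 in one place: quinolin-8-yl in place of naphthalen-1-yl on an amine nitrogen in a ring. Among the measured compounds shown here, no measured step matches this change. For the measured compounds named here, the one step that exists, a 6.0-fold lower number from compound 1 to compound 2 (0.77 log units; beyond the scatter), concerns a different exchange at the same nitrogen and speaks only to the worth of the naphthalen-1-yl group relative to 2,3-dichlorophenyl; it gives no direct reading on replacing a carbon of that bicyclic group by a nitrogen. The step from compound 2 to compound 3 is therefore expected to stay within the scatter or be small, with the direction open. The estimated step is a 1.5-fold higher number from compound 2 to compound 3 (0.18 log units; within the scatter). Compound 3 is expected to give about 30 nM in this assay, with a range from 8 nM to 120 nM.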

Compound 3, inhibition constant: 21 nM
Beside the measured number, compound 3's estimate is 1.4-fold (0.15 log units) above it; the range from low to high includes it.
By their numbers in this assay, from the lowest: compounds 2 and 3 (each within the scatter of the next); then compound 1.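

In this assay, the exchange of naphthalen-1-yl for quinolin-8-yl on the amine nitrogen in the ring gives a 1.1-fold higher number from compound 2 to compound 3 (0.02 log units; within the scatter), so the two groups cannot be told apart here, even though quinolin-8-yl brings a ring nitrogen and a hydrogen-bond acceptor that naphthalen-1-yl lacks. The advantage over 2,3-dichlorophenyl is therefore not tied to naphthalen-1-yl alone: quinolin-8-yl gives a 5.7-fold lower number from compound 1 to compound 3 (0.75 log units; beyond the scatter), and among these three compounds both groups with two fused aromatic rings stand beyond the scatter from the dichlorophenyl compound, with none going against this. Nothing at hand explains why the change from carbon to nitrogen leaves no readable difference.

The compounds shown leave open whether a quinoline joined through a different ring carbon, or a methoxy group or an amine carried on the quinolin-8-yl group, would read the same way in this assay. Going by these compounds, the linking chain and the shared core are the same in all three compounds, so what a shorter chain would do with either of these groups also remains open.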